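Halogen removal from the aryl group of the shared core

The compounds below may be only part of what the source reports. "The series", "measured", "known", "first", "only" and "open" are said of these compounds alone.

Compound 3 `Fc1cc(-c2nnc(C(NCc3ccccc3)c3ccc[nH]3)o2)c(Cl)cc1Cl` gives the lowest number of the three measured in a functional assay on HT-29 cells (Homo sapiens) for cytotoxicity, read by MTT assay, with a stated time of 24 h (on this read-out higher numbers stand for weaker inhibition and lower numbers for stronger inhibition), at 20000 nM; compound 2 `Clc1cccc(-c2nnc(C(NCc3ccccc3)c3ccc[nH]3)o2)c1` sits nearest at 48300 nM and compound 1 `c1ccc(CNC(c2ccc[nH]2)c2nnc(-c3ccccc3)o2)cc1` furthest at 198000 nM. Compound 4 `Cc1cccc(-c2nnc(C(NCc3ccccc3)c3ccc[nH]3)o2)c1` differs from compound 3 in one place: 3-methylphenyl in place of 2,4-dichloro-5-fluorophenyl on an aromatic carbon. The measured steps all run toward halogenated aryls: a 4.1-fold lower number from compound 1 to compound 2 (0.61 log units; beyond the scatter), a 9.9-fold lower number from compound 1 to compound 3 (1.00 log units; beyond the scatter), and a 2.4-fold lower number from compound 2 to compound 3 (0.38 log units; beyond the scatter) between the two substituted aryls. Because a 4.1-fold lower number from compound 1 to compound 2 (0.61 log units; beyond the scatter) and a 9.9-fold lower number from compound 1 to compound 3 (1.00 log units; beyond the scatter) both accompanied halogens entering, compound 4, which carries none, is expected to give a higher number, a step of a 3.5-fold higher number from compound 3 to compound 4 (0.54 log units; beyond the scatter). Compound 4 is therefore estimated at 70000 nM, with a range from 25000 nM to 200000 nM.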

Compound 4, half-maximal inhibitory concentration: 202000 nM
Beside the measured number, compound 4's estimate is 2.9-fold (0.46 log units) below it; the whole stated range lies below it.
By their numbers in this assay, from the lowest: compound 3; then compound 2; then compounds 1 and 4 (each within the scatter of the next).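

In this assay, the lower numbers do not carry over to a non-halogenated substituent at this position: 3-methylphenyl gives a 10-fold higher number from compound 3 to compound 4 (1.00 log units; beyond the scatter), and methyl in place of chloro on an aromatic carbon gives a 4.2-fold higher number from compound 2 to compound 4 (0.62 log units; beyond the scatter). Methyl in place of hydrogen gives a 1.0-fold higher number from compound 1 to compound 4 (0.01 log units; within the scatter), so among these four compounds only the chloro-bearing aryls of compound 2 and compound 3 lower the number. Nothing available explains this difference between chloro and methyl.

Still open, as far as these compounds go, is whether an amine or a carboxylic acid on the aryl group would track with chloro or with methyl.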